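The source may hold more compounds than are shown below. What is called first, only, known or untested is meant among the compounds shown, and "the series" means these compounds.

Three compounds share one core and differ only in the aromatic group on an amine nitrogen in a ring. In a functional assay on A549 cells (Homo sapiens) for antiproliferative activity, read by MTT assay, with a stated time of 72 h (on this read-out lower numbers stand for stronger inhibition and higher numbers for weaker inhibition), compound 1 `Cc1ccccc1N1CCN(C(=S)SCc2ccc3nc(N)nc(N)c3c2)CC1` gives 3920 nM, compound 2 `Cc1ccc(N2CCN(C(=S)SCc3ccc4nc(N)nc(N)c4c3)CC2)c(C)c1` gives 3000 nM and compound 3 `Nc1nc(N)c2cc(CSC(=S)N3CCN(c4ccc(F)cc4F)CC3)ccc2n1` gives 5120 nM. Compound 3 therefore cannot be told apart from the other two, as a 1.3-fold higher number from compound 1 to compound 3 (0.12 log units; within the scatter) and a 1.7-fold higher number from compound 2 to compound 3 (0.23 log units; within the scatter) both stay inside the normal spread of repeat measurements.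

Within the data shown here, compound 4 `Nc1nc(N)c2cc(CSC(=S)N3CCN(c4ccc([N+](=O)[O-])cc4)CC3)ccc2n1` keeps the core and changes only that group: 4-nitrophenyl in place of 2,4-difluorophenyl on an amine nitrogen in a ring. In short, this is 4-nitrophenyl in place of 2,4-difluorophenyl on an amine nitrogen in a ring.

Among the measured compounds shown here, no measured compound carries the 4-nitrophenyl group, so nothing here tests it directly. The closest evidence is the set of changes already made at the same place. Those two steps to compound 3 are joined by the methyl addition, a 1.3-fold lower number from compound 1 to compound 2 (0.12 log units; within the scatter), and none of the three leaves the scatter. On that basis, no step beyond the scatter is expected in this assay, and the data favour no direction. The estimated step is a 1.1-fold lower number from compound 3 to compound 4 (0.06 log units; within the scatter), though a group not yet tried leaves real uncertainty. Compound 4 is expected at 4500 nM, with an estimated range from 1800 nM to 11000 nM.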

Compound 4, half-maximal inhibitory concentration: 1910 nM
The estimate for compound 4 lay 2.4-fold (0.37 log units) above the measured number; the range from low to high includes it.
By their numbers in this assay, from the lowest: compounds 4, 2, 1 and 3 (each within the scatter of the next, the first and the last beyond it).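

Among these compounds, the 4-nitrophenyl group gives the first steps at this place on the amine nitrogen that leave the scatter in this assay, with a 2.7-fold lower number from compound 3 to compound 4 (0.43 log units; beyond the scatter) and a 2.1-fold lower number from compound 1 to compound 4 (0.31 log units; beyond the scatter), so the choice of aromatic group here can shift the number, if only modestly. The shift does not hold against every earlier compound, since a 1.6-fold lower number from compound 2 to compound 4 (0.20 log units; within the scatter) leaves compound 4 and compound 2 indistinguishable, and compound 4 therefore cannot be called the strongest of the set. The change brings in two hydrogen-bond acceptors and a double bond outside the aromatic ring where 2,4-difluorophenyl has neither, but nothing available links either feature to the lower number.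

With one nitro example, the compounds shown leave open whether the step belongs to the nitro group or to the loss of the two fluorines, and how a phenyl ring carrying an amine or a carboxylic acid in place of the nitro group would read. From the compounds shown here alone, all four numbers also come from a single cell type, so whether the same differences appear in other cells remains unknown.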